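This account rests on a few compounds, and the source may have more. Where it says the series, first, only, none or still open, it means among the compounds named here.

Compound 1 `C=CC1=C(C(=O)Nc2ccccc2OC)C(c2ccc(F)cc2)OC1` – > 100000 nM
Compound 2 `C=CC1=C(C(=O)Nc2ccc(C)cc2)C(c2ccc(F)cc2)OC1` – > 100000 nM
Compound 3 `C=CC1=C(C(=O)Nc2ccccc2OC)C(c2ccc(OC)cc2)OC1` – > 100000 nM

Of the compounds shown here, three built on a shared core have been tested in a functional assay on SW480 cells (Homo sapiens) for cytotoxicity, read by MTT assay, with a stated time of 24 h (a higher number here means a weaker inhibitor, a lower number a stronger inhibitor), and a fourth, compound 4 `C=CC1=C(C(=O)Nc2ccc(C)cc2)C(c2ccc(OC)cc2)OC1`, has not yet been measured there. In this assay compound 1 reaches only a limit, > 100000 nM. In this assay compound 2 likewise reaches only a limit, > 100000 nM. In this assay compound 3 also reaches only a limit, > 100000 nM. The change from compound 1 to compound 2 is 4-methylphenyl in place of 2-methoxyphenyl on an amide-type nitrogen, and the step it made in this assay is a step that the two limits leave unreadable from compound 1 to compound 2. The cores of compound 1 and compound 3 differ by methoxy in place of fluoro on an aromatic carbon, and the step belonging to that difference is a step that the two limits leave unreadable from compound 1 to compound 3. From compound 3 to compound 4 the change is 4-methylphenyl in place of 2-methoxyphenyl on an amide-type nitrogen; its place is described in the same words as for the earlier pair, so it is the same change, made now on the core of compound 3 rather than that of compound 1. For the measured compounds named here, since the only evidence here is the limit of > 100000 nM in this assay, at which 3 of the 3 values shown sit, the step from compound 3 to compound 4 cannot be read from the earlier pair. Compound 4 is therefore expected to sit at 200000 nM, most likely as a limit again rather than a number. The step from compound 3 to compound 4 is expected to be a step that the limit leaves unreadable from compound 3 to compound 4, with a range for compound 4 of 60000 nM to 1000000 nM.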

Compound 4, half-maximal inhibitory concentration: > 100000 nM
Compound 4 gave a limit, no number (the forecaster's own chance of this, stated with the estimate: 85%); the middle value is on the limit's open side.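

In this assay compound 4 gives > 100000 nM as a limit and not a number. Neither the step from compound 3 to compound 4 nor the step from compound 2 to compound 4 can be read, because both ends of each pair are limits: the limit of > 100000 nM in this assay, at which 4 of the 4 values shown sit.
The compounds shown leave open how far each of the four lies past that limit, and whether either change shifts the read-out at all.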